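Piperidin-1-yl for Pyrrolidin-1-yl on Compound 3

The compounds below may be only part of what the source reports. "The series", "measured", "known", "first", "only" and "open" are said of these compounds alone.

In a physicochemical assay for lipophilicity, using the shake flask method, measured as octanol-water partition, at pH 7.4 (on this read-out higher numbers stand for higher lipophilicity and lower numbers for lower lipophilicity), compound 1 (`CC(C)n1cc(-c2ccnc3[nH]c(C4CCNCC4)cc23)ccc1=O`) gives -0.2 while compound 2 (`CC(=O)N1CCC(c2cc3c(-c4ccc(=O)n(C(C)C)c4)ccnc3[nH]2)CC1`) gives 2.1 and compound 3 (`CC(C)n1cc(-c2ccnc3[nH]c(C4CCN(CC(=O)N5CCCC5)CC4)cc23)ccc1=O`) gives 2.1 on this scale, so compound 3 stands level with compound 2 at the top of the three. Filling the amine nitrogen in a ring produced a number 2.30 log units higher from compound 1 to compound 2 (beyond the scatter) with acetyl and a number 2.30 log units higher from compound 1 to compound 3 (beyond the scatter) with ((pyrrolidin-1-yl)carbonyl)methyl in its place. Among the compounds with values here, exchanging those two groups gave no change at the digits printed from compound 2 to compound 3 (within the scatter) and is the closest guide, though no measured step alters this ring. Compound 4 (`CC(C)n1cc(-c2ccnc3[nH]c(C4CCN(CC(=O)N5CCCCC5)CC4)cc23)ccc1=O`) carries piperidin-1-yl in place of pyrrolidin-1-yl on a carbonyl carbon and is otherwise unchanged. In this assay a small upward move is expected, an estimated a number 0.40 log units higher from compound 3 to compound 4 (beyond the scatter) and far short of the large steps. Compound 4 is therefore estimated at 2.5 with an expected range from 2.1 to 3 in this measurement.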

Compound 4, distribution coefficient: 2.8
Beside the measured number, compound 4's estimate is 0.30 log units below it; the measured number falls inside the stated range.
By their numbers in this assay, from the lowest: compound 1; then compounds 2 and 3 (each within the scatter of the next); then compound 4.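

In this assay the ring on the carbonyl carbon now proves able to move the number: piperidin-1-yl in place of pyrrolidin-1-yl gives a number 0.70 log units higher from compound 3 to compound 4 (beyond the scatter) and so separates two groups that differ only in ring size. The new group also stands clear of acetyl, with a number 0.70 log units higher from compound 2 to compound 4 (beyond the scatter) on the amine nitrogen in a ring, and gives a number 3.00 log units higher from compound 1 to compound 4 (beyond the scatter) against hydrogen there. Nothing shown explains this rise. As far as these compounds go, whether a morpholin-4-yl ring, an azepan-1-yl ring or an open-chain diethylamino group on the same carbonyl carbon would read higher or lower remains open.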